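Exchanging the bromophenyl amide for a chlorofluorophenyl one

The source may hold more compounds than are shown below. What is called first, only, known or untested is meant among the compounds shown, and "the series" means these compounds.

Measured so far:
compound 1, `O=C(CSc1nc(Nc2ccccc2)c2ccccc2n1)Nc1ccccc1Cl`, 9610 nM
compound 2, `O=C(CSc1nc(Nc2ccccc2)c2ccccc2n1)Nc1ccc(Br)cc1`, 10600 nM

The two compounds share a core and differ only in the aryl group on the amide-type nitrogen. In a functional assay on NCI-H1975 cells (Homo sapiens) for inhibition, read by MTT assay, with a stated time of 72 h (a lower number here means a stronger inhibitor, a higher number a weaker inhibitor), compound 1 gives 9610 nM and compound 2 gives 10600 nM. Compound 2 stands alongside compound 1: the step of a 1.1-fold higher number from compound 1 to compound 2 (0.04 log units; within the scatter) lies within the scatter, so the two numbers are not distinguishable. Compound 3, `O=C(CSc1nc(Nc2ccccc2)c2ccccc2n1)Nc1ccc(F)c(Cl)c1`, carries the change (3-chloro-4-fluorophenyl in place of 4-bromophenyl on an amide-type nitrogen). Going by the values given here, the one measured step, a 1.1-fold higher number from compound 1 to compound 2 (0.04 log units; within the scatter), is the only comparison that bears on it; it swapped one halogenated aryl for another without a shift beyond the scatter. Compound 3 is therefore expected to show no step beyond the scatter in this assay, that is a 1.1-fold lower number from compound 2 to compound 3 (0.03 log units; within the scatter). The estimate for compound 3 in this assay is 10000 nM, with a range from 4000 nM to 25000 nM.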

Compound 3, half-maximal inhibitory concentration: 9390 nM
Compound 3: the middle estimate sits 1.1-fold (0.03 log units) above what was measured; measured number inside the range.
By their numbers in this assay, from the lowest: compounds 3, 1 and 2 (each within the scatter of the next).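

In this assay the exchange of 4-bromophenyl for 3-chloro-4-fluorophenyl gives a 1.1-fold lower number from compound 2 to compound 3 (0.05 log units; within the scatter) and the exchange of 2-chlorophenyl for the same group gives a 1.0-fold lower number from compound 1 to compound 3 (0.01 log units; within the scatter), so none of the three aryl groups can be told apart. The earlier pair compared only aryl groups with a single halogen, whereas this result shows that an aryl carrying both fluorine and chlorine on the amide-type nitrogen also stays within the scatter of both. Nothing available explains why these numbers stay so close.

The compounds shown leave open whether an unsubstituted phenyl, or a phenyl carrying a methoxy group, an amine or a carboxylic acid, would move the number beyond the scatter. They also leave open whether a change elsewhere on the shared core would do so.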